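This account rests on a few compounds, and the source may have more. Where it says the series, first, only, none or still open, it means among the compounds named here.

Measured compounds: compound 1 `Nc1cccc(-c2cn3nc(Cc4ccc(Cl)cc4)sc3n2)c1`, 25000 nM; compound 2 `CCc1ccc(-c2nn3cc(-c4cccc(N)c4)nc3s2)cc1`, 8100 nM; compound 3 `C=C(Br)C(=O)Nc1cccc(-c2cn3nc(Cc4ccc(Cl)cc4)sc3n2)c1`, 2700 nM.

In a functional assay on HeLa cells (Homo sapiens) for inhibition, read by cell counting, with a stated time of 4 days (on this read-out higher numbers stand for weaker inhibition and lower numbers for stronger inhibition), compound 1 stands highest of the three numbers shown; compound 2 and compound 3 both give lower numbers. For the measured compounds named here, the one step measured in one place is a 9.3-fold lower number from compound 1 to compound 3 (0.97 log units; beyond the scatter), which changes the aniline nitrogen rather than the halogenated ring. Compound 4 `COc1ccc(Cc2nn3cc(-c4cccc(N)c4)nc3s2)cc1` differs from compound 1 by methoxy in place of chloro on an aromatic carbon. Going by the values given here, no measured pair changes the same group, so nothing in these data tells how large such a step should be. Compound 4 is therefore expected to stay near compound 1, with no change at the digits printed from compound 1 to compound 4 (within the scatter) expected to fall within the scatter. For compound 4 the estimate in this assay is 25000 nM, with a range from 8000 nM to 70000 nM.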

Compound 4, half-maximal inhibitory concentration: 191000 nM
Compound 4: middle estimate off by 7.6-fold (0.88 log units), on the low side; measured number above the stated range.
By their numbers in this assay, from the lowest: compound 3; then compound 2; then compound 1; then compound 4.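

In this assay, methoxy in place of chloro on the aromatic carbon gives a 7.6-fold higher number from compound 1 to compound 4 (0.88 log units; beyond the scatter), so this position on the ring, which the earlier step on the aniline nitrogen left untouched, is shown to respond to a change. The change goes towards weaker inhibition, the opposite direction to that earlier step. No measurement shown accounts for this.

As far as these compounds go, it remains open how an amine, a carboxylic acid or a longer chain in place of chloro would read. From the compounds shown here alone, it is also open whether (1-bromoethenyl)carbonyl on the nitrogen of compound 4 would lower its number as it does for compound 1.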